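The compounds below may be only part of what the source reports. "The series", "measured", "known", "first", "only" and "open" are said of these compounds alone.

Measured in an ADME assay on the whole organism (plasma, Rattus norvegicus, strain Sprague-Dawley) for protein binding; on this read-out higher numbers stand for a larger free fraction and lower numbers for a smaller free fraction:

- Compound 1 `Nc1nc2c(s1)CCC[C@H]2C(=O)Nc1ccc(C[C@@H]2CC[C@H]([C@H](O)c3ccccc3)N2)cc1`: 0.14
- Compound 2 `Nc1nc2c(s1)CC[C@H]2C(=O)Nc1ccc(C[C@@H]2CC[C@H]([C@H](O)c3cccnc3)N2)cc1`: no result reported
- Compound 3 `Cc1nc2c(s1)CC[C@H]2C(=O)Nc1ccc(C[C@@H]2CC[C@H]([C@H](O)c3ccccc3)N2)cc1`: 0.05

Only two of these compounds have numbers, and compound 3 holds the lower one. Compound 4 `Cc1nc2c(s1)CC[C@H]2C(=O)Nc1ccc(C[C@@H]2CC[C@H]([C@H](O)c3cccnc3)N2)cc1` has not yet been measured. It differs from compound 3 by pyridin-3-yl in place of phenyl on a saturated chain carbon bound to an oxygen on a saturated carbon and a saturated ring carbon, with pyridin-3-yl in place of phenyl on a saturated chain carbon bound to an oxygen on a saturated carbon and a saturated ring carbon.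

Within the data shown here, the only measured step is a 2.8-fold lower number from compound 1 to compound 3 (0.45 log units; beyond the scatter). It is a modest step, but it concerns the group on a carbonyl carbon, not the aromatic ring that changes here, so it gives only a rough sense of how far a single change can move this read-out. Among the measured compounds shown here, compound 2 also carries pyridin-3-yl, but without a result it cannot show what this swap does, and no measured pair isolates the change. The direction is therefore a judgement and not something the data show. A small rise in this assay, not beyond the scatter, is expected, estimated as a 1.6-fold higher number from compound 3 to compound 4 (0.20 log units; within the scatter). For compound 4 the expected value is 0.08, with an estimated range from 0.04 to 0.16.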

Compound 4, unbound fraction: 0.11
Beside the measured number, compound 4's estimate is 1.4-fold (0.14 log units) below it, and the stated range covers the measured number.
By their numbers in this assay, from the lowest: compound 3; then compounds 4 and 1 (each within the scatter of the next).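

In this assay, the place on a saturated chain carbon bound to an oxygen on a saturated carbon and a saturated ring carbon now has its first measured change: pyridin-3-yl in place of phenyl gives a 2.2-fold higher number from compound 3 to compound 4 (0.34 log units; beyond the scatter). The earlier compounds shown here showed only a change in the group on a carbonyl carbon, a 2.8-fold lower number from compound 1 to compound 3 (0.45 log units; beyond the scatter), so this result adds a second place where a single change moves the number beyond the scatter, and it moves the number the opposite way, toward a larger free fraction. Nothing given here accounts for the rise, which stands as an observation from this one pair of compounds.

This single pair leaves open whether pyridin-3-yl in place of phenyl gives a step of the same direction and size on the core of compound 1, or on any other core. It also leaves open how the read-out would respond at this place to other groups, such as pyridin-4-yl, pyrimidin-5-yl or a phenyl ring carrying an amine or a carboxylic acid.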